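The source may report more compounds than this note shows. Statements on the series, on what has been measured and on what is new or still open speak of the compounds shown alone.

- compound 1 `CCC1C(=O)N(C)c2cnc(-n3ccc4cc(C(=O)NC)ccc43)nc2N1c1ccn(C)n1` gives 13300 nM
- compound 2 `CCCCNS(=O)(=O)c1ccc(Nc2ncc3c(n2)N(c2ccn(C)n2)C(CC)C(=O)N3C)cc1` gives 4240 nM
- compound 3 `CCC1C(=O)N(C)c2cnc(Nc3ccc(S(N)(=O)=O)cc3)nc2N1c1ccn(C)n1` gives "not active" (no number reported)

Within the data shown here, these results come from a functional assay on K562 cells (Homo sapiens) for antiproliferative activity, read by CCK-8 assay, with a stated time of 72 h (on this read-out lower numbers stand for stronger inhibition of growth and higher numbers for weaker inhibition of growth), and only two of them are numbers. Compound 1 at 13300 nM stands highest of those two, and compound 2 at 4240 nM lies lower by more than the usual scatter. Compound 3 has no number to place beside them.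

The next compound to be tested, compound 4 (`CCC1C(=O)N(C)c2cnc(-n3ccc4cc(C(=O)NC5CCCC5)ccc43)nc2N1c1ccn(C)n1`), keeps the core of compound 1 and carries cyclopentyl in place of methyl on an amide-type nitrogen. Among the measured compounds shown here, no pair of measured compounds differs in a single place, so nothing shows directly what such a change does in this assay and any forecast is loose. A modest lowering of the number is expected, and it may not clear the scatter. For the measured compounds named here, the only support is that compound 2 at 4240 nM shows a lower number is reachable in this set, while compound 3 with "not active" (no number reported) shows that activity can also be lost. The expected change is a 2.2-fold lower number from compound 1 to compound 4 (0.35 log units; beyond the scatter) in this estimate. For compound 4 the estimated value is 6000 nM with an expected range from 1800 nM to 20000 nM (an estimate, not a measurement).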

Compound 4, concentration for 50% growth inhibition: 31300 nM
For compound 4 the middle estimate is 5.2-fold (0.72 log units) below the measured one, outside the stated range (above it).
By their numbers in this assay, from the lowest: compound 2; then compound 1; then compound 4.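

In this assay, among these compounds, the exchange of methyl for cyclopentyl on the amide-type nitrogen gives a 2.4-fold higher number from compound 1 to compound 4 (0.37 log units; beyond the scatter) and is the first single change in this set that can be read directly. It shows that this position responds to the group it carries, and that here the larger cyclopentyl, which brings a ring of carbon only and no hydrogen-bond donor or acceptor, moves the number towards weaker inhibition of growth, although the step is modest. No measurement in this set accounts for the direction of the step.

On these data alone, with only methyl and cyclopentyl to compare at this nitrogen, it remains open whether the higher number follows from any larger carbon group or is particular to cyclopentyl, and ethyl, cyclopropyl or a longer open chain would help to separate those two readings. As far as these compounds go, it is equally open how this position would respond to a group of a different kind, such as a chain ending in an amine or a carboxylic acid, or whether the same exchange would have a similar effect on a more active compound.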